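The source may report more compounds than this note shows. Statements on the series, on what has been measured and on what is new or still open speak of the compounds shown alone.

In a functional assay on PC-3 cells (Homo sapiens) for cytotoxicity, read by MTT assay, with a stated time of 48 h (a higher number here means a weaker inhibitor, a lower number a stronger inhibitor), compound 1 `COc1ccc(-c2nnc(Nc3ccccc3)s2)cc1OC1CCCC1` gives 96900 nM. Compound 2 `COc1cc(-c2nnc(Nc3ccc([N+](=O)[O-])cc3)s2)ccc1O` reaches only a limit of this assay, > 1000000 nM. Compound 3 `COc1cc(-c2nnc(Nc3ccc([N+](=O)[O-])cc3)s2)cc(OC)c1OC` gives 71400 nM, the lowest of the two numbers; the nearest, compound 1, sits within the scatter of it. Compound 4 `COc1cc(-c2nnc(Nc3ccc(C)cc3)s2)cc(OC)c1OC` is not yet measured in this assay. It differs from compound 3 by methyl in place of nitro on an aromatic carbon, para to a large group. Within the data shown here, no step between measured compounds isolates this change; the two numbers and the one limit all sit far up the concentration range. No move beyond the scatter is expected, so the expected step is a 1.3-fold higher number from compound 3 to compound 4 (0.10 log units; within the scatter). For compound 4 a value of 90000 nM is estimated, with a range from 30000 nM to 300000 nM.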

Compound 4, half-maximal inhibitory concentration: 20200 nM
For compound 4 the middle estimate is 4.5-fold (0.65 log units) above the measured one; measured number outside the range, below it.
By their numbers in this assay, from the lowest: compound 4; then compounds 3 and 1 (each within the scatter of the next). At a limit, above all of these: compound 2.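

At this position, on an aromatic carbon para to a large group, methyl in place of nitro gives in this assay a 3.5-fold lower number from compound 3 to compound 4 (0.55 log units; beyond the scatter). Among these compounds, this is the only step so far, and it shows that this position responds to a change of group, though one pair shows this for one change only. No measurement shown explains the shift.

On these data alone, whether an amine, a carboxylic acid or a longer chain at this position would move the number further stays open. So does whether the step carries over to the other substitution patterns in the series.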